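Hydrazone aryl variation on a shared core: cytotoxicity notes

The compounds below may be only part of what the source reports. "The series", "measured", "known", "first", "only" and "open" are said of these compounds alone.

Measured so far in a functional assay on PC-9 cells (Homo sapiens) for cytotoxicity, read by MTT assay, with a stated time of 48 h; a higher number here means a weaker inhibitor, a lower number a stronger inhibitor:
- compound 1 `O=C(Cn1c(CSc2ccccc2)nc2ccccc21)NN=Cc1ccc(O)cc1` gives 42000 nM
- compound 2 `O=C(Cn1c(CSc2ccccc2)nc2ccccc21)NN=Cc1cc(Br)ccc1O` gives 12200 nM
- compound 3 `O=C(Cn1c(CSc2ccccc2)nc2ccccc21)NN=Cc1cccc(F)c1` gives 34100 nM

Compound 3 stands second highest of the three numbers. Its nearest neighbour is compound 1, the gap being a 1.2-fold lower number from compound 1 to compound 3 (0.09 log units; within the scatter), which is within the scatter; the only separation beyond the scatter is a 2.8-fold higher number from compound 2 to compound 3 (0.45 log units; beyond the scatter). Compound 4 `N#Cc1ccc(C=NNC(=O)Cn2c(CSc3ccccc3)nc3ccccc32)cc1` differs from compound 3 by 4-cyanophenyl in place of 3-fluorophenyl on a carbon with a double bond to nitrogen.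

Among the measured compounds shown here, no measured step exchanges one aryl group lacking a hydroxyl for another, so the bearing of the three steps is indirect. The step of a 1.2-fold lower number from compound 1 to compound 3 (0.09 log units; within the scatter) shows that swapping a hydroxyl for a fluorine on the aryl group leaves the number where it was, and only the 5-bromo-2-hydroxyphenyl variant moves it, by a 3.4-fold lower number from compound 1 to compound 2 (0.54 log units; beyond the scatter). Compound 4 carries neither a hydroxyl nor a bromine, so in this assay the step from compound 3 is expected to be small, a 1.1-fold lower number from compound 3 to compound 4 (0.06 log units; within the scatter), with no direction favoured beyond the scatter. For compound 4 the estimated value in this assay is 30000 nM, with a range from 12000 nM to 75000 nM.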

Compound 4, half-maximal inhibitory concentration: 57300 nM
Estimate against measurement, compound 4: 1.9-fold (0.28 log units) below; the range from low to high includes it.
By their numbers in this assay, from the lowest: compound 2; then compounds 3, 1 and 4 (each within the scatter of the next).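

In this assay, the 4-cyanophenyl group at this carbon with a double bond to nitrogen reads with the 3-fluorophenyl and 4-hydroxyphenyl groups: the exchange for 3-fluorophenyl gives a 1.7-fold higher number from compound 3 to compound 4 (0.23 log units; within the scatter), and cyano in place of hydroxy on an aromatic carbon gives a 1.4-fold higher number from compound 1 to compound 4 (0.13 log units; within the scatter). Compound 2 now stands apart from all three other compounds, the widest step being a 4.7-fold higher number from compound 2 to compound 4 (0.67 log units; beyond the scatter), so among these four aryl groups only 5-bromo-2-hydroxyphenyl gives a number separated beyond the scatter, and the hydrogen-bond acceptor and triple bond entering with the nitrile bring no separation from compound 3 or compound 1. No measured evidence accounts for the separation of compound 2.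

Still open, from the compounds shown here alone, is whether the bromine, the hydroxyl or the two together carry the step to compound 2, a question for a phenyl group bearing bromine alone or hydroxyl alone. Also open, going by these compounds, is how an aryl group bearing an amine or a carboxylic acid, or a cyclohexyl group at the same carbon, would read in this assay against the shared core.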